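This account rests on a few compounds, and the source may have more. Where it says the series, first, only, none or still open, it means among the compounds named here.

Measured compounds:
- compound 1 `O=c1[nH]cc(S(=O)(=O)Nc2ccccc2-c2cn(-c3ccccc3Cl)nn2)c(=O)[nH]1`: 20800 nM in an ADME assay on GES1 cells (Homo sapiens) for cytotoxicity, read by MTT assay, with a stated time of 24 h; on this read-out lower numbers stand for higher toxicity in this test and higher numbers for lower toxicity in this test
- compound 2 `O=c1[nH]cc(S(=O)(=O)Nc2cccc(-c3cn(-c4ccccc4F)nn3)c2)c(=O)[nH]1`: "not toxic" (no number reported) in this assay, with no number given

Within the data shown here, compound 2 therefore has no value to stand on; compound 1 is the only compound with a number in this assay. Compound 3 `O=c1[nH]cc(S(=O)(=O)Nc2cccc(-c3cn(-c4cccc(Cl)c4)nn3)c2)c(=O)[nH]1` differs from compound 2 by 3-chlorophenyl in place of 2-fluorophenyl on an aromatic nitrogen. Among the measured compounds shown here, with no measured step between compounds to guide this change, no shift beyond the scatter is expected in this assay, and compound 3 is expected to remain of low toxicity. Compound 3 is estimated at 30000 nM, within a range from 10000 nM to 100000 nM.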

Compound 3, half-maximal cytotoxic concentration: 26200 nM
Compound 3: the middle estimate sits 1.1-fold (0.06 log units) above what was measured, within the range that was stated.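

Among these compounds, compound 2 has no number in this assay, so no step from it to compound 3 can be read, and no other data bear on this result. As far as these compounds go, whether 3-chlorophenyl in place of 2-fluorophenyl changes toxicity in this test stays open.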